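Growth inhibition notes: from compound 1 to compound 4

The source may report more compounds than this note shows. Statements on the series, on what has been measured and on what is new or still open speak of the compounds shown alone.

Compound 1 `COc1cc(/C=C/C(=O)/C=C/c2cc(OC)c(OC)c(OC)c2)ccc1OCc1cn(CCOc2cc(=O)oc3ccccc23)nn1` was measured in a functional assay on COLO 205 cells (Homo sapiens) for inhibition, read by sulforhodamine B assay, with a stated time of 48 h, tested at 50 uM (on this read-out lower numbers stand for less inhibition of growth and higher numbers for more inhibition of growth at the one concentration tested), and gives 86%. Two further analogues of the shared core are on record. Compound 2 `COc1cc(/C=C/C(=O)/C=C/c2ccccc2)ccc1OCc1cn(CCCCCOc2cc(=O)oc3ccccc23)nn1` gives 22% in this assay, and compound 3 `COc1cccc(/C=C/C(=O)/C=C/c2ccc(OCc3cn(CCCOc4cc(=O)oc5ccccc45)nn3)c(OC)c2)c1` gives 52%. Compound 1 therefore stands at the top of the three numbers; its nearest neighbour is compound 3, whose number lies beyond the scatter below it, and compound 2 lies further still. Within the data shown here, no pair of these three differs in only one place, so no single step can be read off between measured compounds.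

The next compound, compound 4 `COc1cccc(/C=C/C(=O)/C=C/c2ccc(OCc3cn(CCOc4cc(=O)oc5ccccc45)nn3)c(OC)c2)c1`, differs from compound 1 in one place: 3-methoxyphenyl in place of 3,4,5-trimethoxyphenyl on a double-bonded chain carbon bound to a double-bonded chain carbon. The change takes away two of the three methoxy groups on one aryl end of the core, leaving the rest of the molecule untouched.

Among the measured compounds, those with fewer methoxy groups on that aryl end, compound 2 with 22% and compound 3 with 52%, fall short of compound 1, though they also carry other differences, so the pattern rests on three compounds only. A downward step beyond the scatter is expected for compound 4, a number 31 percentage points lower from compound 1 to compound 4 (beyond the scatter), because compound 3 with the same 3-methoxyphenyl end gives 52%. Compound 4 is estimated at 55%, with a range from 35% to 75%.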

Compound 4, percent growth inhibition at one concentration: 69%
Compound 4: middle estimate off by 14 percentage points, on the low side, within the range that was stated.
By their numbers in this assay, from the lowest: compound 2; then compound 3; then compound 4; then compound 1.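

In this assay, the series now has a comparison that isolates one change, 3-methoxyphenyl in place of 3,4,5-trimethoxyphenyl on a double-bonded chain carbon bound to a double-bonded chain carbon, and the result is a modest step, a number 17 percentage points lower from compound 1 to compound 4 (beyond the scatter). The earlier compounds shown here could not show this, since each of them also differed from compound 1 elsewhere. The 3,4,5-trimethoxyphenyl group therefore gives the higher number of this pair, but it is not a requirement for growth inhibition at the one concentration tested, as compound 4 still gives 69%. Nothing at hand accounts for the size or direction of this step.

Still open, going by these compounds, is whether the 3-methoxyphenyl result holds on other versions of the shared core, as this single pair offers no test of that. Also open, on these data alone, is how an aryl end carrying an amine or a carboxylic acid in place of 3,4,5-trimethoxyphenyl would read on the core of compound 1.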